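This account rests on a few compounds, and the source may have more. Where it says the series, first, only, none or still open, it means among the compounds named here.

Measured in an assay for inhibition of Amine oxidase [flavin-containing] B (Rattus norvegicus) (a higher number here means a weaker inhibitor, a lower number a stronger inhibitor), so far:
compound 1 `N#CCCn1nc(-c2ccc(OCc3ccccc3)cc2)oc1=O`: 2.2 nM
compound 2 `N#CCn1nc(-c2ccc(OCc3ccccc3)cc2)oc1=O`: 60 nM
compound 3 `CC(C#N)n1nc(-c2ccc(OCc3ccccc3)cc2)oc1=O`: 48000 nM

Compound 3 stands highest of the three numbers. The step to its nearest neighbour was an 800-fold higher number from compound 2 to compound 3 (2.90 log units; beyond the scatter), and the step from the furthest was a 22000-fold higher number from compound 1 to compound 3 (4.34 log units; beyond the scatter), both well beyond the scatter.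

Compound 4 `CC(C#N)Cn1nc(-c2ccc(OCc3ccccc3)cc2)oc1=O` has not been measured. The change is 2-cyanopropyl in place of 1-cyanoethyl on an aromatic nitrogen. Among the measured compounds shown here, two measured steps bear on it. The step of an 800-fold higher number from compound 2 to compound 3 (2.90 log units; beyond the scatter) shows the cost of a methyl on the saturated chain carbon bound to the aromatic nitrogen; in compound 4 that carbon carries no methyl, which removes the feature that set compound 3 apart. The step of a 27-fold higher number from compound 1 to compound 2 (1.44 log units; beyond the scatter) shows that the longer chain of compound 1 is favoured, and compound 4 keeps that chain length. For the measured compounds named here, a large decrease in this assay is therefore expected for compound 4, roughly a 1600-fold lower number from compound 3 to compound 4 (3.20 log units; beyond the scatter), though the methyl on the chain has no direct precedent here. Compound 4 is estimated at 30 nM, with a range from 3 nM to 300 nM.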

Compound 4, half-maximal inhibitory concentration: 2400 nM
The estimate for compound 4 lay 80-fold (1.90 log units) below the measured number; measured number above the stated range.
By their numbers in this assay, from the lowest: compound 1; then compound 2; then compound 4; then compound 3.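

In this assay, shifting the methyl one carbon further from the aromatic nitrogen recovers only part of the loss (a 20-fold lower number from compound 3 to compound 4 (1.30 log units; beyond the scatter)). Compound 4 remains weaker than the shorter unbranched compound 2 (a 40-fold higher number from compound 2 to compound 4 (1.60 log units; beyond the scatter)), so the longer chain does not offset the methyl. The penalty therefore does not belong only to the carbon bound to the aromatic nitrogen, and it is similar in size at both chain carbons, as the step from the unbranched 2-cyanoethyl compound also shows (a 1100-fold higher number from compound 1 to compound 4 (3.04 log units; beyond the scatter)): the same change on two cores in this assay, an 800-fold higher number (2.90 log units; beyond the scatter) from compound 2 to compound 3 and a 1100-fold higher number (3.04 log units; beyond the scatter) from compound 1 to compound 4, 1.4-fold (0.13 log units) apart, within the scatter of two such steps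

Still open, going by these compounds, is whether a longer unbranched chain ending in a nitrile would extend the gain seen with compound 1. Also open, on these data alone, is whether a fluorine or a hydroxyl on the same chain carbon would carry the same cost as methyl.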